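Phenyl to Pyridin-2-yl Swap on Two Related Cores

The compounds below may be only part of what the source reports. "The series", "measured", "known", "first", "only" and "open" are said of these compounds alone.

Three compounds were measured:
Compound 1, `Cn1nc(N)c2c(=O)[nH]c(-c3ccccc3)cc21`: 9%
Compound 2, `Cn1nc(N)c2c(=O)[nH]c(-c3ccccn3)cc21`: -4%
Compound 3, `Nc1c2c(=O)[nH]c(-c3ccccc3)cc2nn1-c1ccccc1`: 13%

All three were tested in an assay on isolated protein for inhibition of ribosomal protein S6 kinase alpha-5 (Homo sapiens), read by mobility shift assay, tested at 30 uM; on this read-out lower numbers stand for less inhibition and higher numbers for more inhibition at the one concentration tested (going by the name of the read-out). None reaches a strong read-out there. Compound 1 and compound 2 share a core and differ by pyridin-2-yl in place of phenyl on an aromatic carbon; this change gave a number 13 percentage points lower from compound 1 to compound 2 (beyond the scatter). Compound 3 carries a different core; how the two cores differ is not broken down here. Its number is within the scatter of that of compound 1, and beyond the scatter of that of compound 2, so no order between compound 3 and compound 1 can be claimed.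

Compound 4, `Nc1c2c(=O)[nH]c(-c3ccccn3)cc2nn1-c1ccccc1`, has not yet been measured. It is related to compound 3 by pyridin-2-yl in place of phenyl on an aromatic carbon, the same change as from compound 1 to compound 2, at a place described in the same words. Going by the values given here, only that one earlier example of the change is available, so the expectation rests on it alone. Compound 4 is expected to show a number 13 percentage points lower from compound 3 to compound 4 (beyond the scatter), a step of about the size seen in a number 13 percentage points lower from compound 1 to compound 2 (beyond the scatter), because compound 3 starts from 13% and the same change lowered the read-out on the other core. Compound 4 is therefore estimated at 0% in this assay, with a likely range from -12% to 12%.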

Compound 4, a percentage reported as inhibition, at one concentration (the size of the read-out at that concentration, not a potency): 4%
Compound 4: the middle estimate sits 4 percentage points below what was measured; the range from low to high includes it.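

In this assay, pyridin-2-yl in place of phenyl on the aromatic carbon gave a number 9 percentage points lower from compound 3 to compound 4 (within the scatter), and this step can be set beside the one seen earlier on the other core: the same change on two cores in this assay, a number 13 percentage points lower (beyond the scatter) from compound 1 to compound 2 and a number 9 percentage points lower (within the scatter) from compound 3 to compound 4, 4 percentage points apart, within the scatter of two such steps

Going by these compounds alone, the two steps therefore cannot be told apart, which fits the change carrying from one core to the other without a detectable difference, although only the step on the core of compound 1 is beyond the scatter. This does not establish that the swap lowers the read-out on the core of compound 3 taken alone, and a pair of examples on two cores, all with weak read-outs at one concentration, gives no general rule for the series.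

The compounds shown leave open how another group on that aromatic carbon, such as an amine, a carboxylic acid or a longer chain, would read in this assay. They also leave open whether any member of this series reaches a strong read-out there, and so whether the swap would give a step of similar size on a compound with a much higher starting number.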